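A few compounds are considered here, and "the series" means these few. Any claim that something is new, unique, unknown or untested is made for them only; others in the source may bear on it.

Of the compounds shown here, three have been measured in an assay on HEK293 cells for antagonist activity at P2X purinoceptor 7 (Homo sapiens), read by fluorescence, with a stated time of 2 h (a lower number here means a stronger inhibitor, a higher number a weaker inhibitor), and a fourth is still open. Compound 1 `CNC(=O)c1cccc(S(=O)(=O)Oc2ccc(-c3cncn3C3CCN(C(=O)c4ccc([N+](=O)[O-])cc4)CC3)cc2)c1` gives 62 nM in this assay. Compound 2 `CNC(=O)c1cccc(S(=O)(=O)Oc2ccc(-c3cncn3C3CCN(C(=O)c4ccc(N(C)C)cc4)CC3)cc2)c1` shares the core of compound 1 and differs from it only in one place: dimethylamino in place of nitro on an aromatic carbon. In this assay compound 2 gives 25 nM, so that the step of a 2.5-fold lower number from compound 1 to compound 2 (0.39 log units; beyond the scatter) is a modest gain.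

Compound 3 `O=C(c1ccc([N+](=O)[O-])cc1)N1CCC(c2nc3cc(OS(=O)(=O)c4cccc5cnccc45)ccc3[nH]2)CC1` is built on a different core; the difference between the two cores is not broken down here. In this assay compound 3 gives 13 nM, the lowest of the three numbers, though the gap to compound 2 lies within the scatter, while the gap to compound 1 is beyond it.

Compound 4 `CN(C)c1ccc(C(=O)N2CCC(c3nc4cc(OS(=O)(=O)c5cccc6cnccc56)ccc4[nH]3)CC2)cc1` is the still unmeasured partner of compound 3, carrying the same change that turned compound 1 into compound 2: dimethylamino in place of nitro on an aromatic carbon. The place of the change is described in the same words for both pairs, so it counts as the same change on a different core. Because the step of a 2.5-fold lower number from compound 1 to compound 2 (0.39 log units; beyond the scatter) was a modest gain, a step of similar size, a 2.2-fold lower number from compound 3 to compound 4 (0.34 log units; beyond the scatter), is expected from compound 3 to compound 4, resting on that single earlier pair alone. Compound 4 is therefore estimated to give 6 nM in this assay, most likely between 2.5 nM and 15 nM.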

Compound 4, half-maximal inhibitory concentration: 41 nM
Compound 4: the middle estimate sits 6.8-fold (0.83 log units) below what was measured, and the stated range ends below it.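

On the core of compound 3, dimethylamino in place of nitro gives a 3.2-fold higher number from compound 3 to compound 4 (0.50 log units; beyond the scatter), so the inhibitor becomes weaker, whereas the same change made it stronger on the core of compound 1. Set side by side, the two steps point in opposite directions and differ by more than repeated measurements would scatter, so in this assay this change does not carry a fixed effect from one core to the other: the same change on two cores in this assay, a 2.5-fold lower number (0.39 log units; beyond the scatter) from compound 1 to compound 2 and a 3.2-fold higher number (0.50 log units; beyond the scatter) from compound 3 to compound 4, 7.8-fold (0.89 log units) apart, beyond the scatter of two such steps What this does not show is which part of the cores decides the direction of the step, or why it turns round, for the difference between the cores is not broken down and each core offers only a single pair.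

The compounds shown leave open whether other groups in the same place, such as a plain amino group, a methoxy group or a carboxylic acid, would follow the order seen on one core, the other, or neither. Also open, as far as these compounds go, is whether a compound carrying only part of the difference between the two cores would behave like compound 1 and compound 2 or like compound 3 and compound 4.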